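The source may report more compounds than this note shows. Statements on the series, on what has been measured and on what is new or still open speak of the compounds shown alone.

In a functional assay on K562 cells (Homo sapiens) for antiproliferative activity, read by MTT assay, with a stated time of 48 h (a higher number here means a weaker inhibitor, a lower number a stronger inhibitor), compound 1 `Clc1ccc(Nc2nc(Nc3cn[nH]c3)ncc2Cl)cc1` gives 1700 nM. Compound 2 `Clc1cccc(Nc2nc(Nc3cn[nH]c3)nc3ccccc23)c1` reads > 8300 nM, and this is a limit of the assay, not a number. Compound 3 `c1ccc(Nc2nc(Nc3cn[nH]c3)nc3[nH]ccc23)cc1` gives 370 nM, the lower of the two true numbers in the set. The gap between compound 3 and its nearest neighbour, compound 1, lies beyond the usual scatter of repeated measurements.

The next compound starts from compound 3. Compound 4 `Clc1ccccc1CNc1nc(Nc2cn[nH]c2)nc2[nH]ccc12` keeps the shared core and carries 2-chlorobenzyl in place of phenyl on a nitrogen on an aromatic ring. Among the compounds with values here, no measured pair in the set changes only one place, so the data give no direct guide to the size of this step. The expectation therefore rests on the spread of the three readings and on compound 3 holding the best reading at 370 nM, which leaves more of the measured range on the weaker side. In this assay the expected change is a moderate loss of potency, probably just beyond the scatter, with the estimated step of a 2.7-fold higher number from compound 3 to compound 4 (0.43 log units; beyond the scatter). The estimate for compound 4 is 1000 nM, with an expected range from 220 nM to 4500 nM.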

Compound 4, half-maximal inhibitory concentration: 3720 nM
Compound 4: middle estimate off by 3.7-fold (0.57 log units), on the low side; measured number inside the range.
By their numbers in this assay, from the lowest: compound 3; then compound 1; then compound 4. At a limit, above all of these: compound 2.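

Within the data shown here, putting 2-chlorobenzyl in place of phenyl on a nitrogen on an aromatic ring gives the first single-place comparison in this set, and in this assay it reads a 10-fold higher number from compound 3 to compound 4 (1.00 log units; beyond the scatter). The earlier compounds shown here differed in more than one place, so they could not tie a change in the number to this position; this pair shows that the number here responds to the group on that nitrogen, with the shared core held constant. Both groups carry one six-membered aromatic ring of carbon only and no hydrogen-bond donors or acceptors, and compound 2 remains the only compound at a limit, which is not a number: the limit of > 8300 nM in this assay, at which 1 of the 4 values shown sits.

The step joins two changes in one group, the chlorine and the benzyl carbon, and what the compounds shown leave open is how a plain benzyl or a 2-chlorophenyl would read on this nitrogen, either of which would help to separate them. Also open, as far as these compounds go, is whether an amine or a carboxylic acid on the phenyl ring would keep the reading of compound 3 at 370 nM.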